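Compound 1 to compound 3: a carbamoyl swap

This account rests on a few compounds, and the source may have more. Where it says the series, first, only, none or still open, it means among the compounds named here.

Going by the values given here, compound 1 `Cc1cc(NC(=O)Nc2ccccc2OC(F)(F)F)c2ccccc2n1` and compound 2 `Cc1cc(NC(=O)Nc2cccc([N+](=O)[O-])c2)c2ccccc2n1` are the only measured members so far. In an ADME assay on HEK293 cells (Homo sapiens) for cytotoxicity, with a stated time of 72 h (a lower number here means that less compound is needed, a higher number that more compound is needed for the effect), compound 1 gives > 25000 nM, which is a limit of the assay and not a number. In this assay compound 2 gives > 25000 nM, also a limit. The series therefore stands entirely at one reading: the limit of > 25000 nM in this assay, at which 2 of the 2 values shown sit. Among the compounds with values here, compound 1 has no numeric value, and no measured step gives a size to carry over.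

The next compound is compound 3 `Cc1cc(NC(=O)Nc2ccccc2C(N)=O)c2ccccc2n1`. It has carbamoyl in place of trifluoromethoxy on an aromatic carbon, ortho to a large group, with the shared core unchanged: carbamoyl in place of trifluoromethoxy on an aromatic carbon.

No step beyond the scatter is expected, in either direction. This expectation rests on compound 1 and its limit of > 25000 nM, the only anchor available for this change. The estimated step, a number no higher from compound 1 to compound 3 (the limit leaves the size open), is expected to stay within the scatter. A reported limit is the most likely outcome. For compound 3 the estimated value is 25000 nM, with an expected range of 12000 nM to 50000 nM.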

Compound 3, half-maximal effective concentration: > 25000 nM
Compound 3: a limit, no number; the forecaster's own chance of this, stated with the estimate: 85%; the middle value sits exactly at the limit.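

In this assay compound 3 gives > 25000 nM as a limit of the assay and not a number. Compound 1 and compound 3 both stand at limits, so no new step can be read between them. Still open is how far any compound shown lies from that limit in this assay and whether any change on the shared core gives a numeric value.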